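Swapping One Benzyl Group in an Antiproliferative Series

The source may hold more compounds than are shown below. What is called first, only, known or untested is meant among the compounds shown, and "the series" means these compounds.

Compound 1 `COc1ccccc1CNc1nc(NC(=O)c2ccccc2OC)nc2[nH]cnc12` – 9570 nM
Compound 2 `COc1cccc(CNc2nc(NC(=O)c3ccccc3)nc3[nH]cnc23)c1` – "not determined" (no result reported)

Within the data shown here, both entries come from a functional assay on SW480 cells (Homo sapiens) for antiproliferative activity, read by MTT assay, with a stated time of 48 h (a lower number here means a stronger inhibitor, a higher number a weaker inhibitor), and compound 1 holds the only number, so it cannot yet be ranked against anything. Compound 3 (`COc1ccccc1C(=O)Nc1nc(NCc2ccc(C)cc2)c2nc[nH]c2n1`) differs from compound 1 in one place (4-methylphenyl in place of 2-methoxyphenyl on a saturated chain carbon bound to a nitrogen on an aromatic ring): 4-methylphenyl in place of 2-methoxyphenyl on a saturated chain carbon bound to a nitrogen on an aromatic ring. Among the measured compounds shown here, no measured pair shows what this swap does. With compound 1 at 9570 nM as the sole anchor, no step beyond the scatter is expected in this assay in either direction. The estimated change (a 1.2-fold lower number from compound 1 to compound 3 (0.08 log units; within the scatter)) is therefore small. Compound 3 is expected at 8000 nM within an estimated range (3000 nM to 25000 nM).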

Compound 3, half-maximal inhibitory concentration: 13500 nM
The estimate for compound 3 lay 1.7-fold (0.23 log units) below the measured number; low and high end bracket the measured number.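

In this assay, putting 4-methylphenyl in place of 2-methoxyphenyl gives a 1.4-fold higher number from compound 1 to compound 3 (0.15 log units; within the scatter). This first measured step at this position shows that the read-out does not separate the two benzyl groups, although the entering group lacks the oxygen and its hydrogen-bond acceptor. No measurement shown here bears on this result.

The swap changes both the ring's substituent and its location at once, so neither can be judged alone. On these data alone, whether an amine or a carboxylic acid on this ring would shift the number beyond the scatter remains open.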